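From 1-phenylethyl to 1-cyclohexylethyl on a shared core

The source may hold more compounds than are shown below. What is called first, only, known or untested is meant among the compounds shown, and "the series" means these compounds.

Measured in a functional assay for inhibition, with Rattus norvegicus as the target; on this read-out lower numbers stand for stronger inhibition and higher numbers for weaker inhibition:
Compound 1 `C[C@@H](/N=c1\c(O)c(O)\c1=N/c1ccc(C#N)cc1)C(C)(C)C` gives 370 nM; 24300 nM (2 entries)
Compound 2 `C/N=c1\c(O)c(O)\c1=N/c1ccc(C#N)cc1` gives > 30000 nM (a limit)
Compound 3 `C[C@H](/N=c1\c(O)c(O)\c1=N/c1ccc(C#N)cc1)c1ccccc1` gives > 30000 nM (a limit)

Compound 3 reaches only a limit (> 30000 nM) and has no exact place on the scale. Its place is the limit of > 30000 nM in this assay, at which 2 of the 3 values shown sit, and nothing finer. Among the measured compounds shown here, the one measured step (a step that the two limits leave unreadable from compound 2 to compound 3) has no readable size. Compound 4 `C[C@@H](/N=c1\c(O)c(O)\c1=N/c1ccc(C#N)cc1)C1CCCCC1` differs from compound 3 by one change (1-cyclohexylethyl in place of 1-phenylethyl on a double-bonded nitrogen) in the group on the double-bonded nitrogen. In this assay compound 1 also lacks an aromatic ring in that group and gives 370 nM; 24300 nM (2 entries) as its entries. A step towards stronger inhibition is therefore expected (an at least 10-fold lower number from compound 3 to compound 4 (1.00 log units; beyond the scatter)) though its size remains uncertain. The expected range stays wide because the several entries of compound 1 in this assay, 370 nM; 24300 nM (2 entries) lie far apart. Compound 4 is estimated (3000 nM) to fall between 300 nM and 30000 nM as its expected range.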

Compound 4, half-maximal inhibitory concentration: 2600 nM
Compound 4: the middle estimate sits 1.2-fold (0.06 log units) above what was measured; low and high end bracket the measured number.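

In this assay, exchanging the aromatic ring of 1-phenylethyl for the non-aromatic ring of 1-cyclohexylethyl on the double-bonded nitrogen gives an at least 11-fold lower number from compound 3 to compound 4 (1.06 log units; beyond the scatter), with the count of heavy atoms unchanged. Replacing methyl with 1-cyclohexylethyl gives an at least 11-fold lower number from compound 2 to compound 4 (1.06 log units; beyond the scatter). Among the compounds shown here, these are the first readable steps at this position, as the step between the two compounds at the limit cannot be read.

Going by these compounds, how compound 4 ranks against compound 1 stays open: the several entries of compound 1 in this assay, 370 nM; 24300 nM (2 entries). The compounds shown also leave open how an amine on the ring or a straight hexyl chain would fare here.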